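Ester side-chain variation in a diterpenoid butenolide series

The source may hold more compounds than are shown below. What is called first, only, known or untested is meant among the compounds shown, and "the series" means these compounds.

Measured compounds in a functional assay on PC-3 cells (Homo sapiens) for inhibition, read by MTT assay, with a stated time of 48 h; a lower number here means a stronger inhibitor, a higher number a weaker inhibitor:
compound 1 `C=C1CC[C@@H]2[C@](C)(CO)[C@H](O)CC[C@@]2(C)[C@@H]1CC(Sc1ccc(F)cc1)C1=CCOC1=O` gives 16000 nM
compound 2 `C=C1CC[C@@H]2[C@](C)(CO)[C@H](O)CC[C@@]2(C)[C@@H]1CC(Sc1ncccn1)C1=CCOC1=O` gives 7000 nM
compound 3 `C=C1CC[C@@H]2[C@](C)(CO)[C@H](O)CC[C@@]2(C)[C@@H]1C/C=C1/C(=O)OC[C@H]1OC(=O)CSc1ccc(C)cc1` gives 27000 nM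

Compound 3 carries the highest number of the three in this assay. Against compound 1 the gap is within the scatter, so no order between these two can be read; against compound 2 the gap is beyond the scatter, so compound 2 sits clearly lower than compound 3.

Among the compounds with values here, the only step measured within one change is a 2.3-fold lower number from compound 1 to compound 2 (0.36 log units; beyond the scatter), a modest shift on a thioether directly attached to the core. Compound 4 `C=C1CC[C@@H]2[C@](C)(CO)[C@H](O)CC[C@@]2(C)[C@@H]1C/C=C1/C(=O)OC[C@H]1OC(=O)CCCSc1cccs1` differs from compound 3 by 2-((thiophen-2-yl)sulfanyl)ethyl in place of (4-methylphenyl)sulfanyl on a saturated chain carbon bound to a carbonyl carbon. Within the data shown here, this change sits on the ester side chain, remote from the position altered from compound 1 to compound 2, and no measured pair reports on that part of the molecule. Among the measured compounds shown here, the single modest step available gives no reason to expect more than a shift near the scatter, in either direction.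

For compound 4 the estimate in this assay is 22000 nM, range 8000 nM to 60000 nM, which amounts to an expected step of a 1.2-fold lower number from compound 3 to compound 4 (0.09 log units; within the scatter).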

Compound 4, half-maximal inhibitory concentration: 16000 nM
Compound 4: the middle estimate sits 1.4-fold (0.14 log units) above what was measured; measured number inside the range.
By their numbers in this assay, from the lowest: compound 2; then compounds 1, 4 and 3 (each within the scatter of the next).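

In this assay, within the data shown here, this is the first reading on the ester side chain: a 1.7-fold lower number from compound 3 to compound 4 (0.23 log units; within the scatter) stays within the scatter, so 2-((thiophen-2-yl)sulfanyl)ethyl in place of (4-methylphenyl)sulfanyl on a saturated chain carbon bound to a carbonyl carbon gives no readable change. The swap alters the aromatic ring and the chain together, ((4-methylphenyl)sulfanyl)methyl becoming 3-((thiophen-2-yl)sulfanyl)propyl, so this flat result holds for the pair as a whole and cannot be divided between ring and chain. No evidence is available to explain the result.

Open, as far as these compounds go, is whether this side chain responds to any change at all, for instance an amine or a carboxylic acid in place of 2-((thiophen-2-yl)sulfanyl)ethyl. Also open, from the compounds shown here alone, is how the ester compounds relate to the thioether compounds, since no single change links the two groups.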